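Carboxylic Acid Replaces the Hydroxyhexyl Chain

The compounds below may be only part of what the source reports. "The series", "measured", "known", "first", "only" and "open" are said of these compounds alone.

Compound 3 `CCC(CC)(c1ccc(OCCCCCCO)c(C)c1)c1ccc(OCC(O)C(C)(C)C)c(OCC(O)C(C)(C)C)c1` gives 52% in an assay on cells for binding affinity to vitamin D3 receptor (Homo sapiens), read by fluorescence, tested at 1 uM (on this read-out lower numbers stand for less inhibition and higher numbers for more inhibition at the one concentration tested (going by the name of the read-out)), the second highest of three numbers: compound 2 `CCC(CC)(c1ccc(OCCCCO)c(C)c1)c1ccc(OCC(O)C(C)(C)C)c(OCC(O)C(C)(C)C)c1` gives 71% and compound 1 `CCC(CC)(c1ccc(OCCO)c(C)c1)c1ccc(OCC(O)C(C)(C)C)c(OCC(O)C(C)(C)C)c1` gives 38%. The steps among them, a number 33 percentage points higher from compound 1 to compound 2 (beyond the scatter), a number 14 percentage points higher from compound 1 to compound 3 (beyond the scatter) and a number 19 percentage points lower from compound 2 to compound 3 (beyond the scatter), change only the length of a hydroxyalkyl chain, yet they run from modest to large in both directions. Compound 4 `CCC(CC)(c1ccc(OCC(=O)O)c(C)c1)c1ccc(OCC(O)C(C)(C)C)c(OCC(O)C(C)(C)C)c1` brings a different change, (carboxy in place of 5-hydroxypentyl on a saturated chain carbon bound to an oxygen on an aromatic ring). Within the data shown here, no measured step involves a carboxy, so the chain steps bear only indirectly; the shortest chain, in compound 1 with 38%, gave the lowest number, and compound 4 also carries a short group. Compound 4 is thus expected to drop, a number 14 percentage points lower from compound 3 to compound 4 (beyond the scatter), with an estimate of 38% between 15% and 62%.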

Compound 4, a percentage reported as inhibition, at one concentration (the size of the read-out at that concentration, not a potency): 10%
Compound 4: the middle estimate sits 28 percentage points above what was measured; measured number below the stated range.
By their numbers in this assay, from the lowest: compound 4; then compound 1; then compound 3; then compound 2.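

The carboxy end group lowers the number against every hydroxyalkyl chain, with a number 42 percentage points lower from compound 3 to compound 4 (beyond the scatter) and a number 61 percentage points lower from compound 2 to compound 4 (beyond the scatter) and also a number 28 percentage points lower from compound 1 to compound 4 (beyond the scatter) in this assay. The hydroxyalkyl chains alone never reached so low a number, so this position responds to the kind of end group as well as to chain length. Nothing measured here says why the carboxy has this effect.

Chain length and end group change together in these steps, so their shares in the drop stay apart only by guess. A carboxylic acid on a longer chain, or an amine at the chain end, could separate them.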